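Trifluoromethyl in Place of tert-Butyl: An Expected Potency

The source may report more compounds than this note shows. Statements on the series, on what has been measured and on what is new or still open speak of the compounds shown alone.

Compound 1 `CC(C)(C)c1ccc(N2C(N)=NC(N)=NC2(C)C)cc1` is the starting point. In an assay for inhibition of Dihydrofolate reductase (Rattus norvegicus) (on this read-out higher numbers stand for higher potency (the scale is a negative logarithm) and lower numbers for lower potency), compound 1 gives 6.4. Among the compounds with values here, its only measured neighbour is compound 2 `CC1(C)N=C(N)N=C(N)N1c1ccc(I)cc1`, which carries iodo in place of tert-butyl on an aromatic carbon; in this assay compound 2 gives 6.28. The step of a number 0.12 log units lower from compound 1 to compound 2 (within the scatter) shows that the two numbers sit within the scatter of each other, so compound 1 cannot be set apart from compound 2 on these measurements.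

Compound 3 `CC1(C)N=C(N)N=C(N)N1c1ccc(C(F)(F)F)cc1` has not yet been measured. It differs from compound 1 in one place: trifluoromethyl in place of tert-butyl on an aromatic carbon. Within the data shown here, the only measured step that bears on this change is the one from compound 1 to compound 2, which replaced the same tert-butyl on the same aromatic carbon with a different group and moved the read-out by a number 0.12 log units lower from compound 1 to compound 2 (within the scatter), a change inside the scatter. On that evidence, swapping tert-butyl for trifluoromethyl is expected to leave the read-out roughly where compound 1 stands, with no step beyond the scatter in either direction. Compound 3 is therefore expected to give 6.3 in this assay, within a range from 5.8 to 6.8, an expected step of a number 0.10 log units lower from compound 1 to compound 3 (within the scatter).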

Compound 3, logarithm of the reciprocal of the active concentration, log(1/C): 6.06
Compound 3: the middle estimate sits 0.24 log units above what was measured; the measured number falls inside the stated range.
By their numbers in this assay, from the lowest: compounds 3, 2 and 1 (each within the scatter of the next, the first and the last beyond it).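

The position is not indifferent to the group it carries: in this assay, trifluoromethyl in place of tert-butyl gives a number 0.34 log units lower from compound 1 to compound 3 (beyond the scatter), the only step among these three compounds that clears the usual scatter, and only modestly. Trifluoromethyl in place of iodo gives a number 0.22 log units lower from compound 2 to compound 3 (within the scatter), so compound 2 cannot be separated from either of the other two, and the measured difference lies only between the two ends of the series. The change from tert-butyl to trifluoromethyl leaves the count of heavy atoms the same, and neither group has a hydrogen-bond donor or acceptor, so these simple counts cannot separate compound 1 from compound 3.

Nothing available here says why compound 3 falls below compound 1. With only tert-butyl, iodo and trifluoromethyl shown on this aromatic carbon, it remains open how an amine, a carboxylic acid or a longer chain such as n-hexyl would read in this assay, and whether any of them would stand clear of compound 1.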